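The source may hold more compounds than are shown below. What is called first, only, known or untested is meant among the compounds shown, and "the series" means these compounds.

Compound 1 `O[C@H](c1ccccn1)[C@]1(c2cc(C(F)(F)F)ccn2)C[C@H](O)C1`: 33.3 mL/min/kg
Compound 2 `C[C@]1(O)C[C@@](c2cc(C(F)(F)F)ccn2)([C@H](O)c2ccccn2)C1`: 33.3 mL/min/kg
Compound 3 `C[C@]1(O)C[C@](c2cc(C(F)(F)F)ccn2)([C@@H](O)c2ccccn2)C1`: 33.3 mL/min/kg

All three compounds were measured in an ADME assay on liver for metabolic stability, with Liver microsome (Homo sapiens) as the target, read by LC-MS, using microsomes, with a stated time of 5 h (a higher number here means faster removal of the compound, a lower number slower removal), and compound 3 stands level with compounds 1 and 2 at the digits reported. Compound 4 `C[C@]1(O)C[C@](c2cc(C(F)(F)F)ccn2)([C@H](O)c2ccccn2)C1` has not yet been measured. It keeps the same atoms and bonds as compound 3: the two compounds have the same atoms and bonds and differ only in configuration as drawn: 2 of 3 stereo elements differ; a stereocentre at a saturated ring carbon is drawn R in compound 3 and S in compound 4; a stereocentre at a saturated chain carbon is drawn R in compound 3 and S in compound 4. A stereocentre at a saturated ring carbon is drawn R in compound 3 and S in compound 4, and a stereocentre at a saturated chain carbon changes in the same way.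

Among the measured compounds shown here, the one measured step that bears on this is no change at the digits printed from compound 2 to compound 3 (within the scatter). That step rests on (the fact that compounds 2 and 3 differ only in the configuration as drawn), so it is a close precedent for the change at hand, though only a single case. No shift beyond the scatter is therefore expected in this assay, in either direction. The expected outcome is no change at the digits printed from compound 3 to compound 4 (within the scatter). For compound 4, the estimated clearance is 33.3 mL/min/kg, with an expected range of 22 mL/min/kg to 45 mL/min/kg.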

Compound 4, clearance: 33.3 mL/min/kg
For compound 4 middle estimate and measured number coincide at the digits printed, and the stated range covers the measured number.
By their numbers in this assay, from the lowest: compounds 1, 2, 3 and 4 (each within the scatter of the next).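

Among the compounds shown here, compound 4 widens the single configurational precedent: in this assay the readings are no change at the digits printed from compound 3 to compound 4 (within the scatter) and no change at the digits printed from compound 2 to compound 4 (within the scatter), so the stereoisomer pairs that stand level are no longer confined to one case. The second of these pairs is of this kind: the fact that compounds 2 and 4 differ only in the configuration as drawn. The result also adds a change of another type, methyl in place of hydrogen on a saturated ring carbon, which gives no change at the digits printed from compound 1 to compound 4 (within the scatter).

All four compounds print the same value, so none of these changes separates them in this assay, and the set does not show what would. On these data alone, whether a longer chain in place of that methyl, or an amine or a carboxylic acid on the shared core, would move the clearance remains open.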